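Shortening an Amide Chain: Cytotoxicity Expected to Stay Low

The source may report more compounds than this note shows. Statements on the series, on what has been measured and on what is new or still open speak of the compounds shown alone.

This study looks at how strongly a few compounds harm cultured cells, and compares two that differ by a single small group. Compound 1 `COc1ccc(Sc2cn(-c3ccc4c(c3)B(O)OC4)c3ccccc23)cc1` is the larger of the measured pair. Compound 2 `CCCNC(=O)c1cccn1-c1ccc2c(c1)B(O)OC2` carries a propylamino group on its amide.

In an ADME assay on L929 cells (Mus musculus) for cytotoxicity, read by resazurin assay, with a stated time of 72 h (on this read-out lower numbers stand for stronger inhibition and higher numbers for weaker inhibition), compound 1 gives > 10 ug/mL, which is a limit of the assay rather than a number. In this assay compound 2 gives > 10 ug/mL, again a limit and not a number. So compound 2 stands where every value shown stands: both measured values sit at the same limit (the limit of > 10 ug/mL in this assay, at which 2 of the 2 values shown sit), and neither compound is separated from the other.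

Compound 3 `CCNC(=O)c1cccn1-c1ccc2c(c1)B(O)OC2` is the unmeasured compound. It differs from compound 2 by hydrogen in place of methyl on a saturated chain carbon, two bonds along the chain from an amide-type nitrogen. No step between measured compounds is shown, so the expected step from compound 2 to compound 3 in this assay is none beyond the scatter, a step that the limit leaves unreadable from compound 2 to compound 3. Compound 3 is therefore estimated at 30 ug/mL, with a range from 10 ug/mL to 100 ug/mL, most likely reported again only as a limit.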

Compound 3, half-maximal inhibitory concentration: > 10 ug/mL
Compound 3 ended at the assay's limit; the forecaster's own chance of this, stated with the estimate: 90%; the middle value lies beyond the limit too.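

No step can be read from compound 2 to compound 3, because in this assay each of them stops at a limit and not at a number: the limit of > 10 ug/mL in this assay, at which 3 of the 3 values shown sit. The compounds shown leave open whether going from propylamino to ethylamino changes the harm to these cells at all, and how much compound is needed to reach half-maximal inhibition.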